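The source may report more compounds than this note shows. Statements on the series, on what has been measured and on what is new or still open speak of the compounds shown alone.

Of the compounds shown here, two built on a shared core have been tested in a functional assay on CHO cells for antagonist activity at adenosine receptor A2b (Homo sapiens); a higher number here means a weaker inhibitor, a lower number a stronger inhibitor. Compound 1 `O=C(Nc1ncc(C(=O)O)c2nc(-c3ccco3)nn12)NC1CCCCC1` carries a cyclohexylcarbamoyl group on a nitrogen of the core. In this assay compound 1 reaches only a limit of the measurement, > 30000 nM, so no number is known for it. Compound 2 `COc1ccc(CNc2ncc(C(=O)O)c3nc(-c4ccco4)nn23)cc1` carries a 4-methoxybenzyl group on that nitrogen instead. In this assay compound 2 likewise sits at a limit, > 30000 nM. The step that the two limits leave unreadable from compound 1 to compound 2 cannot be sized, because both values sit at the limit of > 30000 nM in this assay, at which 2 of the 2 values shown sit. Compound 2 therefore stands at the limit, with no number to place it more precisely.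

Compound 3 `O=C(O)c1cnc(NCc2ccc(Cl)cc2)n2nc(-c3ccco3)nc12` differs from compound 2 by chloro in place of methoxy on an aromatic carbon. Among the compounds with values here, the one measured step gives no size, so it offers no direction for this change. Because compound 2 gives only a limit, > 30000 nM, in this assay, compound 3 is expected to stay near that limit as well. The step of a number no higher from compound 2 to compound 3 (the limit leaves the size open) is expected to be none beyond the usual scatter. The estimate for compound 3 in this assay is 30000 nM, with a range from 10000 nM to 100000 nM, and it is most likely that only a limit will again be reported.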

Compound 3, inhibition constant: > 30000 nM
Compound 3 was reported as a limit; the forecaster's own chance of this, stated with the estimate: 85%; the middle value lies on the limit itself.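

In this assay compound 3 gives > 30000 nM, which is a limit and not a number. Within the data shown here, no step from compound 1 or compound 2 to compound 3 can be read, since all three share one limit: the limit of > 30000 nM in this assay, at which 3 of the 3 values shown sit. The compounds shown leave open how strongly each acts and whether swapping methoxy for chloro changes anything.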